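From 4-fluorophenyl to 1H-indol-3-yl

The source may report more compounds than this note shows. Statements on the series, on what has been measured and on what is new or still open speak of the compounds shown alone.

- Compound 1 `COc1cc(-c2cc3nccc(-c4cc(OC)c(OC)c(OC)c4)n3n2)cc(OC)c1OC`: > 10000 nM (a limit)
- Compound 2 `COc1cc(-c2ccnc3cc(-c4ccc(F)cc4)nn23)cc(OC)c1OC`: 1280 nM

Among the measured compounds shown here, in a functional assay on MCF7 cells (Homo sapiens) for inhibition, read by CCK-8 assay, with a stated time of 48 h (a higher number here means a weaker inhibitor, a lower number a stronger inhibitor), compound 2 gives 1280 nM, the only actual number so far. Compound 1 gives > 10000 nM, which is a limit.

Compound 3 `COc1cc(-c2ccnc3cc(-c4c[nH]c5ccccc45)nn23)cc(OC)c1OC` has 1H-indol-3-yl in place of 4-fluorophenyl on an aromatic carbon. For the measured compounds named here, no measured step shows what this swap does, so any expectation is loose. In this assay the expected step is an 8.5-fold lower number from compound 2 to compound 3 (0.93 log units; beyond the scatter), towards a stronger inhibitor and beyond the usual scatter. The estimate for compound 3 is 150 nM, with an expected range of 15 nM to 1500 nM.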

Compound 3, half-maximal inhibitory concentration: 85 nM
The estimate for compound 3 lay 1.8-fold (0.25 log units) above the measured number; the measured number falls inside the stated range.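

In this assay, the group on the aromatic carbon of the five-membered ring clearly matters: replacing 4-fluorophenyl with 1H-indol-3-yl gives a 15-fold lower number from compound 2 to compound 3 (1.18 log units; beyond the scatter). Among the compounds shown here, this is the first measured single change at this position, and it shows that a larger two-ring group with a hydrogen-bond donor can sit there with a much lower number. No measurement shown explains why the number falls.

As far as these compounds go, whether the donor itself matters remains open, and 1-methyl-1H-indol-3-yl at this position would test that. From the compounds shown here alone, how an amine or a carboxylic acid would behave there also remains unknown.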